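This account rests on a few compounds, and the source may have more. Where it says the series, first, only, none or still open, it means among the compounds named here.

Measured compounds:
Compound 1 `NC(=O)c1c(NC(=O)c2ccccc2Cl)sc2c1CCN(Cc1ccc(Cl)cc1Cl)C2` gives 21100 nM in a functional assay on HeLa cells (Homo sapiens) for antiproliferative activity, with a stated time of 24 h; on this read-out higher numbers stand for weaker inhibition and lower numbers for stronger inhibition.
Compound 3 `NC(=O)c1c(NC(=O)c2ccccc2F)sc2c1CCN(Cc1ccc(Cl)cc1Cl)C2` gives 27500 nM in this assay.
Compound 2 `Cc1ccc(C(=O)Nc2sc3c(c2C(N)=O)CCN(Cc2ccc(Cl)cc2Cl)C3)cc1` reaches only a limit in this assay, > 50000 nM.

Compound 1 stands at the lowest of the two numbers shown. Its nearest neighbour is compound 3, and a 1.3-fold higher number from compound 1 to compound 3 (0.12 log units; within the scatter), so the two are not separated. The step of an at least 2.3-fold higher number from compound 1 to compound 2 (0.37 log units; beyond the scatter) is the only one beyond the scatter, and it rests on (the limit of > 50000 nM in this assay, at which 1 of the 3 values shown sits).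

Compound 4 `COc1ccc(NC(=S)N2CCc3c(sc(NC(=O)c4ccccc4Cl)c3C(N)=O)C2)cc1` is not yet measured. It differs from compound 1 in a group of 11 heavy atoms (8 carbon, 1 nitrogen, 1 oxygen, 1 sulfur; one six-membered aromatic ring of carbon only) in place of a group of 9 heavy atoms (7 carbon, 2 chlorine; one six-membered aromatic ring of carbon only), on an amine nitrogen in a ring. Among the compounds with values here, all three measured steps concern the group on the carbonyl carbon; none touches the amine nitrogen in the ring where compound 4 differs, so no measured step bears directly on it. No direction can be drawn from the data; the expectation is therefore set at compound 1 with a wide range, and a limit read-out cannot be excluded. For compound 4 the estimate in this assay is 25000 nM, between 8000 nM and 50000 nM, which is expected to mean a 1.2-fold higher number from compound 1 to compound 4 (0.07 log units; within the scatter).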

Compound 4, half-maximal inhibitory concentration: 36400 nM
For compound 4 the middle estimate is 1.5-fold (0.16 log units) below the measured one; the measured number falls inside the stated range.
By their numbers in this assay, from the lowest: compounds 1, 3 and 4 (each within the scatter of the next). At a limit, above all of these: compound 2.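

Working notes on the series: the amine nitrogen in the ring, untouched by the earlier steps, now has one measured change. In this assay, exchanging 2,4-dichlorobenzyl for the larger group with a double bond outside the aromatic ring gives a 1.7-fold higher number from compound 1 to compound 4 (0.24 log units; within the scatter), so the two compounds are not separated, and for this one pair the read-out does not depend on keeping 2,4-dichlorobenzyl. The compounds shown offer no measured reason for this outcome.

From the compounds shown here alone, it remains open whether a group of a different kind on this nitrogen, such as a plain hydrogen, an acetyl or an aminoethyl chain, would move the number beyond the scatter. Going by these compounds, it is also open whether the same exchange would behave alike with the 4-methylphenyl carbonyl group of compound 2.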